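From 4-methylphenyl to pyridin-2-yl: what compound 4 may give

This account rests on a few compounds, and the source may have more. Where it says the series, first, only, none or still open, it means among the compounds named here.

Of the compounds shown here, three that share one core have been measured in an assay on HEK293 cells for inhibition of Voltage-dependent T-type calcium channel subunit alpha-1G (Homo sapiens), read by fluorescence, tested at 10 uM; a higher number here means more inhibition at the concentration tested (going by the name of the read-out), a lower number less inhibition. Compound 1 `CCCc1nc(-c2ccccc2)c(CNCCN2CCN(c3ccccc3Cl)CC2)o1` gives 60.1% in that setting; compound 2 `CCCc1nc(-c2ccccc2)c(CNCCCN2CCN(c3ccccc3OC)CC2)o1` gives 41%; compound 3 `CCCc1nc(-c2ccccc2)c(CNCCN2CCN(c3ccc(C)cc3)CC2)o1` gives 48.1%. Among these three numbers compound 3 stands second highest: its nearest neighbour is compound 2, whose number is lower by an amount within the scatter, and its furthest is compound 1, whose number is higher by an amount beyond the scatter. Among the measured compounds shown here, the only step measured between compounds that differ in a single place is a number 12 percentage points lower from compound 1 to compound 3 (beyond the scatter), a modest fall.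

Compound 4 `CCCc1nc(-c2ccccc2)c(CNCCN2CCN(c3ccccn3)CC2)o1` has not yet been measured. It differs from compound 3 in one place: pyridin-2-yl in place of 4-methylphenyl on an amine nitrogen in a ring. For the measured compounds named here, no measured step involves pyridin-2-yl, so the only comparison that bears on it is that single modest step, which shows that exchanging the group on this ring nitrogen can move the inhibition by a modest amount. An expectation of no change beyond the scatter, held with wide uncertainty, therefore follows. Compound 4 is expected to give 45%, between 25% and 65%. The expected step of a number 3.1 percentage points lower from compound 3 to compound 4 (within the scatter) is accordingly small.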

Compound 4, a percentage reported as inhibition, at one concentration (the size of the read-out at that concentration, not a potency): 48.1%
Compound 4: the middle estimate sits 3.1 percentage points below what was measured; measured number inside the range.
By their numbers in this assay, from the lowest: compounds 2, 3 and 4 (each within the scatter of the next); then compound 1.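

In this assay, the exchange on the amine nitrogen in a ring gives no change at the digits printed from compound 3 to compound 4 (within the scatter), so at this position pyridin-2-yl, with 6 heavy atoms and 1 hydrogen-bond acceptor, matches 4-methylphenyl, with 7 heavy atoms and 0 hydrogen-bond acceptors, and the nitrogen in the aromatic ring brings no change beyond the scatter. The second new step, a number 12 percentage points lower from compound 1 to compound 4 (beyond the scatter), has the same printed size as the earlier a number 12 percentage points lower from compound 1 to compound 3 (beyond the scatter), which shows that two different replacements of 2-chlorophenyl both fall by an amount beyond the scatter, leaving compound 1 apart from compound 3 and compound 4 in this small set. Nothing offered here gives a reason for either step.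

The compounds shown leave open whether the higher number of compound 1 belongs to the chlorine itself or to where it sits on the aromatic ring, a question that 4-chlorophenyl or 2-methylphenyl on the same nitrogen would address. They also leave open whether this position needs an aromatic ring at all, as a cyclohexyl group or an acetyl group there would show.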